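Swapping the aryl group on the thiophene core once more

This account rests on a few compounds, and the source may have more. Where it says the series, first, only, none or still open, it means among the compounds named here.

Compound 2 `CC(C)(C)Cc1c(-c2ccc(Cl)c(Cl)c2)sc(N)c1C(=O)c1ccc(Cl)cc1` was tested in an assay on CHO cells for displacement of a labelled ligand from adenosine receptor A1 (Homo sapiens), read by scintillation counting, tested at 10 uM (a higher number here means more inhibition at the concentration tested (going by the name of the read-out), a lower number less inhibition), where compound 2 gives 1%. Compound 1 `CC(C)(C)Cc1c(-c2cccnc2)sc(N)c1C(=O)c1ccc(Cl)cc1` is its closest measured neighbour, and in this assay compound 1 gives 1%, so compound 2 stands level with compound 1 at the digits shown. Going by the values given here, the step of no change at the digits printed from compound 1 to compound 2 (within the scatter) is the only measured comparison so far. Compound 3 `Cc1ccc(-c2sc(N)c(C(=O)c3ccc(Cl)cc3)c2CC(C)(C)C)cc1` has not yet been measured; it differs from compound 2 in one place: 4-methylphenyl in place of 3,4-dichlorophenyl on an aromatic carbon. Among the compounds with values here, the single step that bears on this change replaced one aryl group with another at the same position and left the read-out unchanged within the scatter, so a further swap of the aryl group at that position is expected to leave inhibition essentially where it is, with no step in this assay beyond the scatter. Compound 3 is therefore estimated at 1%, between -5% and 12%, a step of no change at the digits printed from compound 2 to compound 3 (within the scatter).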

Compound 3, a percentage reported as inhibition, at one concentration (the size of the read-out at that concentration, not a potency): 1%
Compound 3: middle estimate and measured number agree at the digits printed; the range from low to high includes it.
By their numbers in this assay, from the lowest: compounds 1, 2 and 3 (each within the scatter of the next).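

With a third aryl group at this position, next to the ring sulfur, this assay shows no change at the digits printed from compound 2 to compound 3 (within the scatter), and the comparison with the pyridin-3-yl group shows no change at the digits printed from compound 1 to compound 3 (within the scatter). A methyl group at the 4-position of the phenyl ring therefore joins the 3,4-dichlorophenyl and pyridin-3-yl groups, and across these three compounds the choice of aryl group makes no difference that this read-out can detect. No measurement here explains this result.

On these data alone, all three compounds carry an aryl group at this position, so it remains open whether a carboxylic acid or an aminomethyl group there would raise the inhibition. The compounds shown also leave open whether replacing the neopentyl group with a shorter chain, such as ethyl, would change the read-out.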